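This account rests on a few compounds, and the source may have more. Where it says the series, first, only, none or still open, it means among the compounds named here.

In a functional assay on MDA-MB-435 cells (Homo sapiens) for cytotoxicity, read by MTT assay, with a stated time of 72 h (a higher number here means a weaker inhibitor, a lower number a stronger inhibitor), compound 1 `Nc1cccc(Nc2c(C(=O)NCc3ccc(F)cc3)nc(Br)c3cccnc23)c1` gives 8000 nM. Compound 2 `N[C@H]1CC[C@H](Nc2c(C(=O)NCc3ccco3)nc(Br)c3cccnc23)CC1` reads > 10000 nM, which is a limit of the assay and not a number. Compound 3 `CN(C)CCCNc1c(C(=O)NCc2ccc(F)cc2)nc(Br)c2cccnc12` gives 7000 nM, and its nearest neighbour on this scale is compound 1: a 1.1-fold lower number from compound 1 to compound 3 (0.06 log units; within the scatter).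

Compound 4 `CNCCCNc1c(C(=O)NCc2ccc(F)cc2)nc(Br)c2cccnc12` has hydrogen in place of methyl on an amine nitrogen, (hydrogen in place of methyl on an amine nitrogen). Going by the values given here, no measured step makes this exact change. The closest guide, a 1.1-fold lower number from compound 1 to compound 3 (0.06 log units; within the scatter), swapped a whole group and still moved the number by no more than the scatter. A change this small is therefore expected to shift this assay by no more than the scatter, in neither direction clearly. The expected step is a 1.2-fold lower number from compound 3 to compound 4 (0.07 log units; within the scatter). Compound 4 is estimated at 6000 nM, with an expected range of 2500 nM to 10000 nM.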

Compound 4, half-maximal inhibitory concentration: 11000 nM
For compound 4 the middle estimate is 1.8-fold (0.26 log units) below the measured one; measured number outside the range, above it.
By their numbers in this assay, from the lowest: compounds 3, 1 and 4 (each within the scatter of the next).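

Taking one methyl off the dimethylamino group gives the first direct reading at this amine nitrogen, and this assay shows a 1.6-fold higher number from compound 3 to compound 4 (0.20 log units; within the scatter) and so no clear effect of that methyl. Replacing 3-aminophenyl with 3-(methylamino)propyl on the nitrogen on an aromatic ring gives a 1.4-fold higher number from compound 1 to compound 4 (0.14 log units; within the scatter) and is just as unclear. The scale in this assay also has a limit: the limit of > 10000 nM in this assay, at which 1 of the 4 values shown sits.

On these data alone, it remains open whether a primary amine in place of the methylamino group, or a longer chain carrying the same amine, would give a step beyond the scatter.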